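A Second Fluorine on an Already Fluorinated Ring

The source may report more compounds than this note shows. Statements on the series, on what has been measured and on what is new or still open speak of the compounds shown alone.

Of the compounds shown here, three have been measured in a physicochemical assay for lipophilicity, read by LC-MS, in phosphate buffer, measured as octanol-water partition, with a stated time of 1 h, at pH 7.4; a lower number here means a more polar compound, a higher number a more lipophilic compound. Compound 1 `C[C@H](Nc1cc(F)c(S(=O)(=O)Nc2nccs2)cc1Cl)c1ccccc1` gives 3. Compound 2 `C[C@H](Nc1cc(F)c(S(=O)(=O)Nc2nccs2)cc1Cl)c1ccc(F)cc1` gives 3.1 in this assay. Compound 3 `C[C@H](Nc1cc(F)c(S(=O)(=O)Nc2cscn2)cc1Cl)c1ccccc1F` gives 3.5 in this assay, the highest of the three numbers, with gaps to compound 2 and to compound 1 that both lie beyond the usual scatter of repeated measurements.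

The change from compound 1 to compound 2 is fluoro in place of hydrogen on an aromatic carbon. In this assay it gave a number 0.10 log units higher from compound 1 to compound 2 (within the scatter), a step too small to separate from measurement noise.

Compound 4 `C[C@H](Nc1cc(F)c(S(=O)(=O)Nc2cscn2)cc1Cl)c1cc(F)ccc1F` has not yet been measured. It differs from compound 3 by fluoro in place of hydrogen on an aromatic carbon. Among the measured compounds shown here, this is the same kind of change as the one from compound 1 to compound 2, but not quite the same: in the earlier pair the new fluoro sat para to a large group, whereas here it sits meta to a large group and para to a fluoro group. The difference between the core of compound 3 and the core of compound 1 is not broken down here.

Because the step of a number 0.10 log units higher from compound 1 to compound 2 (within the scatter) was small, the expected step for the new pair is a number 0.20 log units higher from compound 3 to compound 4 (within the scatter), a small rise of the same order. On that basis compound 4 is estimated at 3.7 in this assay, most likely between 3.4 and 4.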

Compound 4, distribution coefficient: 3.5
Estimate against measurement, compound 4: 0.20 log units above; the range from low to high includes it.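

In this assay, the same swap of hydrogen for fluoro, here 2-fluorophenyl to 2,5-difluorophenyl, gave no change at the digits printed from compound 3 to compound 4 (within the scatter), and on the core of compound 1 it gave a number 0.10 log units higher from compound 1 to compound 2 (within the scatter), so on both cores the step stays too small to tell apart from measurement noise. This is a modest sign that the swap carries across these two cores without a step beyond the scatter, but it rests on two pairs only, the new fluoro sits in a different place in each pair, and a step within the scatter does not prove that the true step is zero. Nothing shown here explains why either step came out as it did.

The compounds shown leave open whether the swap would behave the same way with the fluoro para to a large group on the core of compound 3, and how the two cores compare on their own, since compound 1 and compound 3 differ in more than one place. They also leave open whether a group other than fluoro at this place on the ring, such as an amine, a carboxylic acid or a longer chain, would give a step beyond the scatter.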